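From methyl to sulfonyl on the ring amine nitrogen

A few compounds are considered here, and "the series" means these few. Any claim that something is new, unique, unknown or untested is made for them only; others in the source may bear on it.

In an ADME assay on L02 cells (Homo sapiens) for cytotoxicity, read by MTT assay, with a stated time of 24 h (a higher number here means a weaker inhibitor, a lower number a stronger inhibitor), compound 1 `CN1C/C(=C\c2ccncc2)C(=O)/C(=C/c2ccccc2F)C1` gives 14900 nM. Compound 2 `CN1C/C(=C\c2ccncc2)C(=O)/C(=C/c2cc([N+](=O)[O-])ccc2F)C1` gives 17600 nM, and compound 3 `CN1C/C(=C\c2ccncc2)C(=O)/C(=C/c2ccccc2C(F)(F)F)C1` gives 15800 nM. Compound 1 thus stands level with the other two, and the three numbers are not separated from one another.

The next entry is compound 4 `O=C1/C(=C/c2ccncc2)CN(S(=O)(=O)c2ccc(Cl)cc2)C/C1=C\c1ccccc1F`. Its change from compound 1 is (4-chlorophenyl)sulfonyl in place of methyl on an amine nitrogen in a ring.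

Two measured steps are available. Nitro in place of hydrogen on an aromatic carbon gives a 1.2-fold higher number from compound 1 to compound 2 (0.07 log units; within the scatter). Trifluoromethyl in place of fluoro on an aromatic carbon gives a 1.1-fold higher number from compound 1 to compound 3 (0.03 log units; within the scatter). Both lie within the scatter, but both are changes on an aromatic carbon, and neither touches the amine nitrogen. Among the compounds with values here, they bear on compound 4 only indirectly, and no measured compound here carries anything but methyl at that nitrogen.

A step within the scatter is therefore the working expectation, leaning slightly towards a lower number, with a wide margin in both directions. The estimated step is a 1.4-fold lower number from compound 1 to compound 4 (0.13 log units; within the scatter). Compound 4 is expected at 11000 nM, with an estimated range of 3500 nM to 30000 nM.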

Compound 4, half-maximal inhibitory concentration: 15000 nM
Compound 4: the middle estimate sits 1.4-fold (0.13 log units) below what was measured, within the range that was stated.
By their numbers in this assay, from the lowest: compounds 1, 4, 3 and 2 (each within the scatter of the next).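

Notes on the ring amine nitrogen: compound 4 is the first entry varied at this position, and in this assay the change gives a 1.0-fold higher number from compound 1 to compound 4 (0.00 log units; within the scatter). A substantially larger group, (4-chlorophenyl)sulfonyl, with its six-membered aromatic ring and 2 hydrogen-bond acceptors, can therefore stand in place of methyl here with no separation from compound 1 in this read-out. Within the data shown here, until now, the only steps available lay on aromatic carbons, so this extends the flat picture from those positions to the nitrogen, though no reason for the flat result can be given, as nothing available bears on it.

Still open, going by these compounds, is whether this single result reflects the sulfonyl link or the 4-chlorophenyl ring, since the two enter together and a methylsulfonyl, benzyl or acetyl group on the same nitrogen would help separate them. Also open, on these data alone, is how a group of a different kind would read at this position, such as a carboxylic acid or a longer chain ending in an amine, and whether (4-chlorophenyl)sulfonyl would stay level when paired with the nitro or trifluoromethyl aromatic changes.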